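The compounds below may be only part of what the source reports. "The series", "measured", "known", "first", "only" and "open" are said of these compounds alone.

Of the compounds shown here, two built on a shared core have been measured. Compound 1 `COc1cc(-c2cc(/C=C/C(=O)c3ccc(N)cc3)[nH]n2)cc(OC)c1OC` gives 2770 nM in a functional assay on RPMI-8226 cells (Homo sapiens) for inhibition, read by sulforhodamine B assay, with a stated time of 48 h (on this read-out higher numbers stand for weaker inhibition of growth and lower numbers for stronger inhibition of growth), and compound 2 `COc1ccc(C(=O)/C=C/c2cc(-c3cc(OC)c(OC)c(OC)c3)n[nH]2)cc1OC` gives 1110 nM. Among the measured compounds shown here, the single change between them, a 2.5-fold lower number from compound 1 to compound 2 (0.40 log units; beyond the scatter), is the only step available, and compound 2 stands lowest of the two numbers, with compound 1 its nearest measured partner. Compound 3 `COc1ccc(C(=O)/C=C/c2cc(-c3cc(OC)c(OC)c(OC)c3)n[nH]2)cc1` differs from compound 2 by hydrogen in place of methoxy on an aromatic carbon. For the measured compounds named here, the step from compound 1 to compound 2 swapped the whole group on the carbonyl carbon and does not test the loss of one methoxy, so no measured step bears directly on this change. Without a guide, the change is expected to move the number little, a 1.4-fold higher number from compound 2 to compound 3 (0.13 log units; within the scatter), with a slight lean toward a higher number. Compound 3 is therefore estimated at 1500 nM, within a range from 600 nM to 4000 nM.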

Compound 3, concentration for total growth inhibition: 2490 nM
For compound 3 the middle estimate is 1.7-fold (0.22 log units) below the measured one; measured number inside the range.
By their numbers in this assay, from the lowest: compound 2; then compounds 3 and 1 (each within the scatter of the next).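

Taking away one methoxy group, so that 3,4-dimethoxyphenyl becomes 4-methoxyphenyl, gives a 2.2-fold higher number from compound 2 to compound 3 (0.35 log units; beyond the scatter) in this assay, so this aromatic carbon is not indifferent to what it carries, although the step is modest. The other new comparison, methoxy in place of amino, gives a 1.1-fold lower number from compound 1 to compound 3 (0.05 log units; within the scatter), so 4-methoxyphenyl and 4-aminophenyl cannot be told apart here, and among these three compounds the clearly lower number appears only with the 3,4-dimethoxyphenyl group of compound 2. Nothing available explains why the extra methoxy group makes this difference.

As far as these compounds go, it remains open whether methoxy is special at this carbon or whether a hydroxyl, a chlorine or an ethoxy group would serve as well. Whether a 3,4,5-trimethoxyphenyl group would bring the number down further is also unknown.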